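The source may report more compounds than this note shows. Statements on the series, on what has been measured and on what is new or still open speak of the compounds shown alone.

In a functional assay on Jurkat cells (Homo sapiens) (a higher number here means a weaker inhibitor, a lower number a stronger inhibitor), compound 1 `Cc1ccccc1CNC(=O)C(=O)N[C@@H](C)C(=O)N[C@@H](CC(=O)O)C(=O)COc1c(F)c(F)cc(F)c1F` gives 52 nM and compound 2 `Cc1cccc(CNC(=O)C(=O)N[C@@H](C)C(=O)N[C@@H](CC(=O)O)C(=O)COc2c(F)c(F)cc(F)c2F)c1` gives 127 nM, a modest move of a 2.4-fold higher number from compound 1 to compound 2 (0.39 log units; beyond the scatter). Compound 3 `Cc1ccc(CNC(=O)C(=O)N[C@@H](C)C(=O)N[C@@H](CC(=O)O)C(=O)COc2c(F)c(F)cc(F)c2F)cc1C` sits at > 10000 nM, which is a limit of the assay and not a number.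

Compound 4 `C[C@H](NC(=O)C(=O)NCc1cc(F)cc(F)c1)C(=O)N[C@@H](CC(=O)O)C(=O)COc1c(F)c(F)cc(F)c1F` carries 3,5-difluorophenyl in place of 3,4-dimethylphenyl on a saturated chain carbon bound to an amide-type nitrogen. The closest measured evidence is the large at least 78-fold higher number from compound 2 to compound 3 (1.89 log units; beyond the scatter), with the large at least 190-fold higher number from compound 1 to compound 3 (2.28 log units; beyond the scatter) alongside it. Both end at the limit, and the 3,4-dimethylphenyl group leaves in the new change. A large step toward a lower number in this assay is therefore expected, though its size is uncertain with only a limit as the starting point. The expected step is an at least 83-fold lower number from compound 3 to compound 4 (1.92 log units; beyond the scatter). Compound 4 is estimated at 120 nM, within an expected range of 25 nM to 1200 nM.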

Compound 4, half-maximal inhibitory concentration: 16 nM
Beside the measured number, compound 4's estimate is 7.5-fold (0.88 log units) above it, and the stated range ends above it.
By their numbers in this assay, from the lowest: compound 4; then compound 1; then compound 2. At a limit, above all of these: compound 3.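

In this assay, compound 4 with 3,5-difluorophenyl has the lowest number of the series, with a 3.3-fold lower number from compound 1 to compound 4 (0.51 log units; beyond the scatter) and a 7.9-fold lower number from compound 2 to compound 4 (0.90 log units; beyond the scatter). A phenyl ring carrying two substituents at this position is therefore compatible with strong inhibition, as an at least 620-fold lower number from compound 3 to compound 4 (2.79 log units; beyond the scatter) shows. Compound 3 sits at a limit of the assay, so that step is only a bound: the limit of > 10000 nM in this assay, at which 1 of the 4 values shown sits.

Open, on these data alone, is whether the gain follows the fluorines or their arrangement on the ring. 3,5-Dimethylphenyl and 3,4-difluorophenyl at this place would separate the two.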